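Cytotoxicity notes on a carbamoyl-to-ring change in one series

A few compounds are considered here, and "the series" means these few. Any claim that something is new, unique, unknown or untested is made for them only; others in the source may bear on it.

Compound 3 `Cc1cc(C)cc(S(=O)(=O)c2c(C(=O)NC3CC4(CCN(CC(N)=O)CC4)C3)[nH]c3ccc(Cl)cc23)c1` and compound 1 `Cc1cc(C)cc(S(=O)(=O)c2c(C(=O)NC3CC4(CCN(Cc5n[nH]c(=O)n5C)CC4)C3)[nH]c3ccc(Cl)cc23)c1` share one core and differ at a single place: a group of 7 heavy atoms (3 carbon, 3 nitrogen, 1 oxygen; one five-membered aromatic ring with 3 hetero atoms) in place of a group of 3 heavy atoms (1 carbon, 1 nitrogen, 1 oxygen; no ring), on a saturated chain carbon bound to an amine nitrogen in a ring. In a toxicity assay on MT4 cells (Homo sapiens) for cytotoxicity, read by MTT assay, with a stated time of 7 days (a lower number here means that less compound is tolerated, a higher number that more compound is tolerated), compound 3 gives 3610 nM, and compound 1 gives 178000 nM. The change made a 49-fold higher number from compound 3 to compound 1 (1.69 log units; beyond the scatter), so far more of compound 1 is tolerated than of compound 3.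

Compound 2 `Cc1cc(C)cc(S(=O)(=O)c2c(C(=O)NC3CC4(CCN(CC(N)=O)C4)C3)[nH]c3ccc(Cl)cc23)c1` carries the same carbamoyl group as compound 3 but sits on a different core; the difference between the two cores is not broken down here. In this assay compound 2 gives 3700 nM, which is within the scatter of compound 3, so with the carbamoyl group in place the two cores cannot be told apart on this read-out.

Compound 4 `Cc1cc(C)cc(S(=O)(=O)c2c(C(=O)NC3CC4(CCN(Cc5n[nH]c(=O)n5C)C4)C3)[nH]c3ccc(Cl)cc23)c1` has not yet been measured. It is made from compound 2 by the same change: a group of 7 heavy atoms (3 carbon, 3 nitrogen, 1 oxygen; one five-membered aromatic ring with 3 hetero atoms) in place of a group of 3 heavy atoms (1 carbon, 1 nitrogen, 1 oxygen; no ring), on a saturated chain carbon bound to an amine nitrogen in a ring. The place is the same, word for word, as in the measured pair, and the starting number of compound 2 is within the scatter of compound 3. On that basis the step is expected to be a 41-fold higher number from compound 2 to compound 4 (1.61 log units; beyond the scatter), resting on a 49-fold higher number from compound 3 to compound 1 (1.69 log units; beyond the scatter) and on compound 2 at 3700 nM. Going by the values given here, only one measured example of the change exists, so some shrinkage toward a smaller step is allowed for in the range. For compound 4 the expected value in this assay is 150000 nM, with a range from 50000 nM to 400000 nM.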

Compound 4, half-maximal cytotoxic concentration: > 214000 nM
Compound 4 was reported as a limit; the forecaster's own chance of this, stated with the estimate: 10%; middle value at least 1.4-fold (0.15 log units) from the limit.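

In this assay the carbamoyl-to-ring change gives an at least 57-fold higher number from compound 2 to compound 4 (1.76 log units; beyond the scatter) on the second core, so the direction seen on the core of compound 3 carries over to the core of compound 2, and in both pairs the compound with the ring group is tolerated at a far higher concentration than its carbamoyl partner. Compound 4 gives > 214000 nM and this entry is a limit of the assay and not a number, so the new step has a lower bound only. The finding rests on one pair per core and says nothing about cores outside these two, and whether the size of the step depends on the core stays undecided: the same change on two cores in this assay, a 49-fold higher number (1.69 log units; beyond the scatter) from compound 3 to compound 1 and an at least 57-fold higher number (1.76 log units; beyond the scatter) from compound 2 to compound 4; the limit leaves it open whether they differ.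

The compounds shown leave open which part of the ring group carries the step, since only the whole group is set against carbamoyl and no smaller piece of it, such as a plain amine or a carboxylic acid on the same saturated chain carbon, stands beside it. They also leave open whether a longer chain ending in the carbamoyl group would behave like carbamoyl or like the ring group on either core.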